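A few compounds are considered here, and "the series" means these few. Any claim that something is new, unique, unknown or untested is made for them only; others in the source may bear on it.

Measured in a functional assay on COLO 205 cells (Homo sapiens) for inhibition, read by sulforhodamine B assay, with a stated time of 48 h, tested at 50 uM; a higher number here means more inhibition of growth at the concentration tested, a lower number less inhibition of growth:
- compound 1 `COc1ccc(/C=C/C(=O)/C=C/c2ccc(OCc3cn(CCCCOc4cc(=O)oc5ccccc45)nn3)c(OC)c2)cc1OC`: 53%
- compound 2 `COc1cc(/C=C/C(=O)/C=C/c2cccc3ccccc23)ccc1OCc1cn(CCCCCOc2cc(=O)oc3ccccc23)nn1`: 40%

Compound 2, at 40%, is the lower of the two measured compounds. The gap to compound 1, at 53%, lies beyond the usual scatter of this assay.

The next compound is compound 3 `COc1ccc(/C=C/C(=O)/C=C/c2ccc(OCc3cn(CCCCCOc4cc(=O)oc5ccccc45)nn3)c(OC)c2)cc1`. It departs from compound 2 by one change: 4-methoxyphenyl in place of naphthalen-1-yl on a double-bonded chain carbon bound to a double-bonded chain carbon. Going by the values given here, no pair of measured compounds differs in a single place, so the data give no direct size for a change of this kind. A modest upward step in this assay is expected, though it may not clear the scatter. Among the compounds with values here, the only guide is the range so far, with compound 2 at 40% at its lower end and compound 1 at 53% at its upper end. This is a weak basis, and a wide range is warranted. The expected shift is a number 6 percentage points higher from compound 2 to compound 3 (within the scatter). For compound 3 the estimated value is 46%, with an expected range of 32% to 60%.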

Compound 3, percent growth inhibition at one concentration: 30%
Compound 3: middle estimate off by 16 percentage points, on the high side, and the stated range ends above it.
By their numbers in this assay, from the lowest: compounds 3 and 2 (each within the scatter of the next); then compound 1.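

In this assay, going by these compounds alone, compounds 2 and 3 form the first pair that differs in one place, and the exchange gives a step that stays inside the scatter (a number 10 percentage points lower from compound 2 to compound 3 (within the scatter)). On a double-bonded chain carbon bound to a double-bonded chain carbon, 4-methoxyphenyl and naphthalen-1-yl are therefore not separated by this read-out at the single concentration tested, even though the exchange goes from 2 six-membered aromatic rings of carbon only to one and adds 1 hydrogen-bond acceptor. No measurement is available that bears on the reason for this result.

Within the data shown here, still open is whether a group of another kind at this place, such as 4-aminophenyl or 4-carboxyphenyl, would give a step beyond the scatter, since the pair covers only two aromatic groups. Also open, as far as these compounds go, is whether the exchange of naphthalen-1-yl for 4-methoxyphenyl would give a similar step on a longer chain, as one pair on one core says nothing about how the change behaves elsewhere.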